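This account rests on a few compounds, and the source may have more. Where it says the series, first, only, none or still open, it means among the compounds named here.

In a functional assay on A549 cells (Homo sapiens) for cytotoxicity, read by colorimetric assay and MTT assay (a higher number here means a weaker inhibitor, a lower number a stronger inhibitor), compound 1 (`CCN(CC)C(=O)Cn1c(=O)c(-c2ccc(OC)cc2)cc2c(OC)cc(OC)cc21`) gives 10000 nM, compound 2 (`COc1ccc(-c2cc3c(OC)cc(OC)cc3n(CC(=O)O)c2=O)cc1`) gives 10000 nM and compound 3 (`COC(=O)CCn1c(=O)c(-c2ccc(OC)cc2)cc2c(OC)cc(OC)cc21`) gives 10000 nM, so compound 3 stands level with both. Compound 4 (`COc1ccc(-c2cc3c(OC)cc(OC)cc3n(CCC#N)c2=O)cc1`), not yet measured, differs from compound 3 by cyano in place of methoxycarbonyl on a saturated chain carbon, two bonds along the chain from an aromatic nitrogen. Three measured steps alter this same substituent on the aromatic nitrogen: no change at the digits printed from compound 1 to compound 2 (within the scatter), no change at the digits printed from compound 1 to compound 3 (within the scatter) and no change at the digits printed from compound 2 to compound 3 (within the scatter). Going by the values given here, none of them leaves the scatter, although no measured compound carries a cyano group. The expected change is none beyond the scatter, with an estimated no change at the digits printed from compound 3 to compound 4 (within the scatter). The estimate for compound 4 is 10000 nM, with an expected range of 4000 nM to 20000 nM.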

Compound 4, half-maximal inhibitory concentration: 10000 nM
Estimate against measurement, compound 4: no gap at the digits printed; the range from low to high includes it.
By their numbers in this assay, from the lowest: compounds 1, 2, 3 and 4 (each within the scatter of the next).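

Cyano in place of methoxycarbonyl gives no change at the digits printed from compound 3 to compound 4 (within the scatter) in this assay, which adds a nitrile to the groups read at this position without a step beyond the scatter. The other side chains read the same way, with no change at the digits printed from compound 2 to compound 4 (within the scatter) for cyanomethyl in place of carboxy and no change at the digits printed from compound 1 to compound 4 (within the scatter) for cyanomethyl in place of diethylcarbamoyl.

Still open, going by these compounds, is whether an amine or a longer chain on the aromatic nitrogen, or a change to the methoxy groups of the shared core, would shift this reading. No measurement at hand accounts for the shared value.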